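Changing the amide of compound 3 to a difluoromethylpiperidine

This account rests on a few compounds, and the source may have more. Where it says the series, first, only, none or still open, it means among the compounds named here.

Measured compounds: compound 1 `O=C([C@@H]1CCCN(S(=O)(=O)c2ccc(S(=O)(=O)C3CCC3)cc2)C1)N1CCC(F)(F)CC1` with > 3000 nM in a functional assay on MIA PaCa-2 cells (Homo sapiens) for inhibition, read by MTT assay, with a stated time of 3 days; a higher number here means a weaker inhibitor, a lower number a stronger inhibitor; compound 2 `CC(C)S(=O)(=O)c1ccc(S(=O)(=O)N2CCC[C@@H](C(=O)N3CCC(F)(F)CC3)C2)cc1` with > 3000 nM; compound 3 `CCN(CC)S(=O)(=O)c1ccc(S(=O)(=O)N2CCC[C@@H](C(=O)N[C@H]3CCOC3)C2)cc1` with > 10000 nM.

All three values are limits of this assay rather than numbers. Compound 1 sits at a limit, (the limit of > 3000 nM in this assay, at which 2 of the 3 values shown sit). Compound 3 sits at the other limit, (the limit of > 10000 nM in this assay, at which 1 of the 3 values shown sits), so it stands at the weakest end of what was recorded, and nothing finer than that is known of it.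

Going by the values given here, the only step between measured compounds is a step that the two limits leave unreadable from compound 1 to compound 2, and it cannot be read in size or direction, since both of its ends are limits. Compound 4 `CCN(CC)S(=O)(=O)c1ccc(S(=O)(=O)N2CCC[C@@H](C(=O)N3CCC(C(F)F)CC3)C2)cc1` differs from compound 3 by 4-(difluoromethyl)piperidin-1-yl in place of (oxolan-3-yl)amino on a carbonyl carbon. Among the compounds with values here, no measured step touches this change directly. Compounds 1 and 2 each carry a piperidine amide on the same core and both sit at a limit, so a piperidine amide on this core gives no sign of measurable inhibition here.

Compound 4 is therefore expected to remain at or near a limit, estimated at 12000 nM with a range of 4000 nM to 40000 nM. The step to compound 4 is expected as a step that the limit leaves unreadable from compound 3 to compound 4, with no readable direction, and most likely this assay will again report only a limit for compound 4.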

Compound 4, half-maximal inhibitory concentration: > 10000 nM
Compound 4: only a limit was reported; the forecaster's own chance of this, stated with the estimate: 85%; the middle value is on the limit's open side.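

In this assay compound 4 gives > 10000 nM, which is a limit of the assay. Compound 3 gives > 10000 nM, also a limit, and no step can be read between compound 3 and compound 4. The compounds shown leave open what the actual inhibition of any of the four is, and whether any change on the shared core gives a readable value.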